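Notes on the series: isopropyl to 4-methoxyphenyl

This account rests on a few compounds, and the source may have more. Where it says the series, first, only, none or still open, it means among the compounds named here.

Measured so far:
- compound 1 `COc1cc(-c2nccn2C(C)C)cc(OC)c1OC` gives > 100000 nM in a functional assay on HT-29 cells (Homo sapiens) for antiproliferative activity, read by MTT assay, with a stated time of 72 h; on this read-out higher numbers stand for weaker inhibition and lower numbers for stronger inhibition; this is a limit of the assay, not a number.
- compound 2 `COc1cc(-c2nccn2S(=O)(=O)c2ccc(C)cc2)cc(OC)c1OC` gives > 100000 nM in this assay; this too is a limit of the assay.
- compound 3 `COc1cc(-c2nccn2-c2ccc3[nH]ccc3c2)cc(OC)c1OC` gives 9100 nM in this assay.

Compound 1 therefore stands at the limit of > 100000 nM in this assay, at which 2 of the 3 values shown sit, and only compound 3 returns a number. Among the measured compounds shown here, no pair of measured compounds differs in a single place, so no measured step is available.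

Compound 4 `COc1ccc(-n2ccnc2-c2cc(OC)c(OC)c(OC)c2)cc1` differs from compound 1 by 4-methoxyphenyl in place of isopropyl on an aromatic nitrogen. Among the measured compounds, the one that carries an aromatic ring on an aromatic nitrogen, compound 3, is the one that gives a number rather than a limit. On that basis a move from the limit toward stronger inhibition is expected, beyond the scatter, with the estimated step from compound 1 to compound 4 being an at least 5.0-fold lower number from compound 1 to compound 4 (0.69 log units; beyond the scatter). Compound 4 is estimated at 20000 nM, with an expected range from 4000 nM to 100000 nM, and a limit remains possible.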

Compound 4, half-maximal inhibitory concentration: 13100 nM
Beside the measured number, compound 4's estimate is 1.5-fold (0.18 log units) above it; the range from low to high includes it.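

In this assay, the position on the aromatic nitrogen now shows its first readable change: 4-methoxyphenyl in place of isopropyl gives an at least 7.6-fold lower number from compound 1 to compound 4 (0.88 log units; beyond the scatter). The step has only a lower bound, since the value of compound 1 is a limit of the assay and not a number: the limit of > 100000 nM in this assay, at which 2 of the 4 values shown sit. The change brings in a six-membered aromatic ring and a hydrogen-bond acceptor together, so this single step does not show which of the two carries the shift.

Open, as far as these compounds go, is whether a plain phenyl, or an amine or a carboxylic acid on the ring in place of the methoxy, would hold this level. Also open, from the compounds shown here alone, is whether a longer alkyl chain on the aromatic nitrogen, with no ring, would stay at the limit.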